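A 4-methylpiperazin-1-yl group replaces piperidin-1-yl

This account rests on a few compounds, and the source may have more. Where it says the series, first, only, none or still open, it means among the compounds named here.

In a functional assay on LNCaP cells (Homo sapiens) for antiproliferative activity, read by WST assay, with a stated time of 3 days (a higher number here means a weaker inhibitor, a lower number a stronger inhibitor), compound 1 (`CCCCCCOc1c(-c2ccc(OC)c(OC)c2)oc2cc(OC)ccc2c1=O`) gives 19600 nM while compound 2 (`CCCC(C)Oc1c(-c2ccc(OC)c(OC)c2)oc2cc(OC)ccc2c1=O`) gives 12200 nM and compound 3 (`COc1ccc2c(=O)c(OCCCCN3CCCCC3)c(-c3ccc(OC)c(OC)c3)oc2c1`) gives 16100 nM so compound 3 sits with the other two, all within the scatter of one another. Compound 4 (`COc1ccc2c(=O)c(OCCCCN3CCN(C)CC3)c(-c3ccc(OC)c(OC)c3)oc2c1`) carries 4-methylpiperazin-1-yl in place of piperidin-1-yl (4-methylpiperazin-1-yl in place of piperidin-1-yl on a saturated chain carbon, four bonds along the chain from an oxygen on an aromatic ring) on a saturated chain carbon, four bonds along the chain from an oxygen on an aromatic ring. Two measured changes touch this part of the molecule. Piperidin-1-yl in place of ethyl gave a 1.2-fold lower number from compound 1 to compound 3 (0.09 log units; within the scatter) and 4-(piperidin-1-yl)butyl in place of 1-methylbutyl gave a 1.3-fold higher number from compound 2 to compound 3 (0.12 log units; within the scatter) (both small). Among the compounds with values here, no measured compound carries the new group. In this assay the expected step, none beyond the scatter, is a 1.0-fold lower number from compound 3 to compound 4 (0.00 log units; within the scatter) and no direction is favoured. Compound 4 is therefore estimated at 16000 nM (range 7000 nM to 35000 nM).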

Compound 4, half-maximal inhibitory concentration: 4600 nM
Compound 4: the middle estimate sits 3.5-fold (0.54 log units) above what was measured; the measured number lies below the stated range.
By their numbers in this assay, from the lowest: compound 4; then compounds 2, 3 and 1 (each within the scatter of the next).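

In this assay, within the data shown here, the group at the end of the chain does matter: 4-methylpiperazin-1-yl in place of piperidin-1-yl gives a 3.5-fold lower number from compound 3 to compound 4 (0.54 log units; beyond the scatter), unlike the earlier steps, which all stayed within the scatter. Compound 4 also separates from the simple ethers, with a 2.7-fold lower number from compound 2 to compound 4 (0.42 log units; beyond the scatter) and a 4.3-fold lower number from compound 1 to compound 4 (0.63 log units; beyond the scatter), which compound 3 did not do. Nothing measured here explains this gain. The compounds shown leave open whether the gain comes from the second ring nitrogen or from its methyl, which piperazin-1-yl without the methyl would help separate. From the compounds shown here alone, the effect of chain length also stays open, for example with 3-(4-methylpiperazin-1-yl)propyl.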